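The source may hold more compounds than are shown below. What is called first, only, known or untested is meant among the compounds shown, and "the series" means these compounds.

Working notes on the series. In a functional assay (strain AB) with Danio rerio as the target, read by microscopy, with a stated time of 1 h (a lower number here means that less compound is needed, a higher number that more compound is needed for the effect), compound 1 `CCN1CCc2c(sc(NC(=O)Nc3ccc(Cl)cc3)c2C(=O)NC)C1` gives > 25000 nM, which is a limit and not a number. Compound 2 `CCN1CCc2c(sc(NC(=O)Nc3ccc(Cl)cc3)c2C(=O)NC2COC2)C1` gives > 25000 nM, which is also a limit. Among the compounds with values here, the position of compound 2 is therefore known only as a limit, and the same holds across the series so far: the limit of > 25000 nM in this assay, at which 2 of the 2 values shown sit.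

Compound 3 `CCN1CCc2c(sc(NC(=O)Nc3ccc(Cl)cc3)c2C(=O)NCCO)C1` carries 2-hydroxyethyl in place of oxetan-3-yl on an amide-type nitrogen. Within the data shown here, the one measured step bearing on this change acts on the same nitrogen, with oxetan-3-yl in place of methyl: a step that the two limits leave unreadable from compound 1 to compound 2. It offers no size and no direction to carry over, so no step beyond the scatter is expected in this assay. The expected step is a number no higher from compound 2 to compound 3 (the limit leaves the size open). A report as a limit is the likeliest outcome in this assay. For compound 3 the estimated value is 25000 nM, with an expected range of 10000 nM to 50000 nM.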

Compound 3, half-maximal effective concentration: 9400 nM
Compound 3: the middle estimate sits 2.7-fold (0.42 log units) above what was measured; measured number below the stated range.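

Within the data shown here, on the amide-type nitrogen, the substituent can change the result in this assay: compound 3, with 2-hydroxyethyl, gives 9400 nM, the first actual number. Placing 2-hydroxyethyl in place of oxetan-3-yl gives an at least 2.6-fold lower number from compound 2 to compound 3 (0.42 log units; beyond the scatter), and hydroxymethyl in place of hydrogen on the saturated chain carbon bound to that nitrogen gives an at least 2.6-fold lower number from compound 1 to compound 3 (0.42 log units; beyond the scatter). Both sizes are open-ended and the step between compound 1 and compound 2 cannot be read, because those two compounds sit at a limit: the limit of > 25000 nM in this assay, at which 2 of the 3 values shown sit.

The compounds shown do not separate the gain of the hydroxyl from the loss of the oxetane ring, and the full size of either step remains open. As far as these compounds go, how a methoxyethyl group, a longer hydroxyalkyl chain or an aminoethyl group on the same nitrogen would read in this assay is also open.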